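The source may report more compounds than this note shows. Statements on the series, on what has been measured and on what is new or still open speak of the compounds shown alone.

Measured compounds:
compound 1, `CSc1nc(NCCCc2ccccc2)c2ccccc2n1`: 77200 nM
compound 2, `CSc1nc(NCc2ccc([Se]C)cc2)c2ccccc2n1`: 36400 nM

Both compounds were tested in a functional assay on MCF7 cells (Homo sapiens) for cytotoxicity, read by MTT assay, with a stated time of 72 h; a higher number here means a weaker inhibitor of growth, a lower number a stronger inhibitor of growth. Compound 1 gives 77200 nM, the higher of the two numbers, while compound 2 gives 36400 nM; the gap between the two lies beyond the usual scatter, so compound 2 is the stronger inhibitor of growth of the pair. The two structures differ in more than one place, so the gap cannot be tied to any single change.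

Compound 3, `CSc1nc(NCCCCCO)c2ccccc2n1`, has not yet been measured in this assay. It differs from compound 1 in one place: 2-hydroxyethyl in place of phenyl on a saturated chain carbon, three bonds along the chain from a nitrogen on an aromatic ring. Within the data shown here, no measured pair shows the effect of this change, so the expectation rests on the weak growth inhibition of compound 1 alone. The step of a 1.3-fold higher number from compound 1 to compound 3 (0.11 log units; within the scatter) is expected to be small, if anything toward a higher number. Compound 3 is therefore expected to give about 100000 nM, within a range from 40000 nM to 250000 nM.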

Compound 3, concentration for 50% growth inhibition: 62000 nM
Beside the measured number, compound 3's estimate is 1.6-fold (0.21 log units) above it, and the stated range covers the measured number.
By their numbers in this assay, from the lowest: compounds 2, 3 and 1 (each within the scatter of the next, the first and the last beyond it).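

Replacing phenyl with 2-hydroxyethyl at this place gives, in this assay, a 1.2-fold lower number from compound 1 to compound 3 (0.10 log units; within the scatter) and so leaves the number unchanged within the scatter. The aromatic ring in compound 1 can therefore give way to a ring-free group carrying a hydrogen-bond donor and acceptor without a measurable loss or gain in growth inhibition, and growth inhibition stays weak in both compounds. Nothing available explains why this swap leaves the number so little changed.

On these data alone, it remains open whether any group in this place can move the number beyond the scatter, for example an amine, a carboxylic acid or a longer chain. The compounds shown also leave open whether a substituted phenyl would behave like phenyl or like 2-hydroxyethyl here.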